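Fluoro for bromo on the piperazine phenyl ring

A few compounds are considered here, and "the series" means these few. Any claim that something is new, unique, unknown or untested is made for them only; others in the source may bear on it.

Compound 1 `CCCn1c(=O)[nH]c2nc(-c3ccc(S(=O)(=O)N4CCN(c5ccc(F)cc5)CC4)cc3)[nH]c2c1=O` carries a 4-fluorophenyl on the piperazine amine nitrogen. In an assay on CHO cells for displacement of a labelled ligand from adenosine receptor A3 (Homo sapiens), read by scintillation counting, with a stated time of 45 min, in the presence of a further agent that is not named here (a higher number here means a weaker inhibitor, a lower number a stronger inhibitor), compound 1 gives only a limit, > 1000 nM. Compound 2 `CCCn1c(=O)[nH]c2nc(-c3ccc(S(=O)(=O)N4CCN(c5ccccc5Br)CC4)cc3)[nH]c2c1=O` has a 2-bromophenyl in place of the 4-fluorophenyl on that amine nitrogen. In this assay compound 2 also gives only a limit, > 1000 nM. The step that the two limits leave unreadable from compound 1 to compound 2 therefore cannot be read. Among the measured compounds shown here, compound 2 thus stands at the assay limit, and the one further value shown sits at the same limit (the limit of > 1000 nM in this assay, at which 2 of the 2 values shown sit).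

Compound 3 `CCCn1c(=O)[nH]c2nc(-c3ccc(S(=O)(=O)N4CCN(c5ccccc5F)CC4)cc3)[nH]c2c1=O` is the next member: fluoro in place of bromo on an aromatic carbon, which cut one bond further out reads 2-bromophenyl to 2-fluorophenyl. For the measured compounds named here, the only measured step, from compound 1 to compound 2, is unreadable, and both its members sit at the limit, so no size or direction beyond the scatter can be drawn from it for this assay. Compound 3 is therefore expected to remain at or near the limit, with an estimated step that the limit leaves unreadable from compound 2 to compound 3. The estimate for compound 3 is 3000 nM, with a range from 800 nM to 15000 nM.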

Compound 3, inhibition constant: > 1000 nM
Compound 3: a limit, no number; the forecaster's own chance of this, stated with the estimate: 80%; the middle value lies beyond the limit too.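

Compound 3 gives > 1000 nM in this assay, a limit and not a number, so no step among compound 1, compound 2 and compound 3 can be read: the limit of > 1000 nM in this assay, at which 3 of the 3 values shown sit.

The compounds shown leave open how far past this limit each one lies, and whether any group on the phenyl ring would give a measurable value.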